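Trifluoromethyl to Methyl: Expected Cytotoxicity of Compound 4

The source may report more compounds than this note shows. Statements on the series, on what has been measured and on what is new or still open speak of the compounds shown alone.

Measured so far in a functional assay on A549 cells (Homo sapiens) for cytotoxicity, read by MTT assay, with a stated time of 68 h; a higher number here means a weaker inhibitor, a lower number a stronger inhibitor:
Compound 1, `O=C(Nc1cccc(-c2ccccc2C(F)(F)F)c1)C(Cl)Cl`, gives 7500 nM.
Compound 3, `COc1ccccc1-c1cc(NC(=O)C(Cl)Cl)cc(-c2ccccc2OC)c1`, gives 25500 nM.
Compound 2, `O=C(Nc1cccc(-c2ccc(-c3ccccc3)cc2)c1)C(Cl)Cl`, gives > 50000 nM, which is a limit of the assay rather than a number.

Among the two numbers, compound 1 has the lowest, and the nearest, compound 3, sits at a gap beyond the usual scatter. Compound 2 contributes only a limit (the limit of > 50000 nM in this assay, at which 1 of the 3 values shown sits). Compound 4, `Cc1ccccc1-c1cccc(NC(=O)C(Cl)Cl)c1`, differs from compound 1 in one place: methyl in place of trifluoromethyl on an aromatic carbon. For the measured compounds named here, no pair of measured compounds differs in just this way, so the size of this step in this assay is open; a small shift toward a higher number, within or just beyond the scatter, seems most likely. Compound 4 is therefore expected to give about 12000 nM, between 4000 nM and 40000 nM. The expected step is a 1.6-fold higher number from compound 1 to compound 4 (0.20 log units; within the scatter).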

Compound 4, half-maximal inhibitory concentration: 9860 nM
Beside the measured number, compound 4's estimate is 1.2-fold (0.09 log units) above it; low and high end bracket the measured number.
By their numbers in this assay, from the lowest: compounds 1 and 4 (each within the scatter of the next); then compound 3. At a limit, above all of these: compound 2.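

In this assay, the step from trifluoromethyl to methyl on this aromatic carbon, ortho to a large group, comes to a 1.3-fold higher number from compound 1 to compound 4 (0.12 log units; within the scatter). For the compounds shown here, this is the first direct reading of a change at this position, and it shows that the two groups cannot be told apart here, even with the fluorine atoms gone. Nothing measured here accounts for this step. From the compounds shown here alone, whether an amine or a carboxylic acid on the same carbon would stay within the scatter of compound 1 remains open. So does the outcome for a longer chain there.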